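A few compounds are considered here, and "the series" means these few. Any claim that something is new, unique, unknown or untested is made for them only; others in the source may bear on it.

Working notes on the series. Compound 1 `CC(C)(C)OC(=O)NCCCCN(CCCN(Cc1ccc(F)cc1)Cc1ccc(F)cc1)CCCN(Cc1ccc(F)cc1)Cc1ccc(F)cc1` is the open-chain member; in an ADME assay on RAW264.7 cells (Mus musculus) for cytotoxicity, read by resazurin assay, with a stated time of 48 h (on this read-out lower numbers stand for higher toxicity in this test and higher numbers for lower toxicity in this test), compound 1 gives 12000 nM. Compound 2 `CC(C)(C)OC(=O)NC1CCC(N(CCCN(Cc2ccc(F)cc2)Cc2ccc(F)cc2)CCCN(Cc2ccc(F)cc2)Cc2ccc(F)cc2)CC1` carries the same capped amine on a saturated ring. In this assay compound 2 gives > 100000 nM, which is a limit of the assay and not a number. So the position of compound 2 on the numbers shown is known only as the limit of > 100000 nM in this assay, at which 1 of the 2 values shown sits, and compound 2 is the one of the two that sits there. For the measured compounds named here, the two measured compounds differ in more than one place, so no single step between them is set out; their two values show only that compound 1 has a number and compound 2 a limit.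

Compound 3 `NC1CCC(N(CCCN(Cc2ccc(F)cc2)Cc2ccc(F)cc2)CCCN(Cc2ccc(F)cc2)Cc2ccc(F)cc2)CC1` is the next member. It differs from compound 2 by hydrogen in place of tert-butoxycarbonyl on an amine nitrogen. With no measured step of this kind in the series, the direction is open; the expectation is a step from compound 2 to compound 3 of an at least 2.5-fold lower number from compound 2 to compound 3 (0.39 log units; beyond the scatter) toward the more toxic side, modest rather than large, and possibly still a limit. The value expected for compound 3 in this assay is 40000 nM, in a range of 10000 nM to 100000 nM.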

Compound 3, half-maximal cytotoxic concentration: 4500 nM
Compound 3: the middle estimate sits 8.9-fold (0.95 log units) above what was measured; measured number below the stated range.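

In this assay, for the compounds shown here, the change of tert-butoxycarbonyl to hydrogen on an amine nitrogen is the first single-place change that can be read, and it goes toward the more toxic side, giving an at least 22-fold lower number from compound 2 to compound 3 (1.34 log units; beyond the scatter). That size is a bound and not a full measure, as the value of compound 2 is a limit of the assay and not a number: the limit of > 100000 nM in this assay, at which 1 of the 3 values shown sits.

The second step, 4-aminocyclohexyl in place of 4-((tert-butoxycarbonyl)amino)butyl on an amine nitrogen, gives a 2.7-fold lower number from compound 1 to compound 3 (0.43 log units; beyond the scatter), which places the uncapped ring amine on the more toxic side of the capped open-chain member as well, though this step alters the ring and the cap together and cannot separate them.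

Open, on these data alone, is whether the shift belongs to the free amino group as such, or whether an acetyl cap or a dimethylamino group at the same place would read the same way. Also open, as far as these compounds go, is where an uncapped butylamine chain would stand in this assay, a value that would divide the step between the cap and the ring.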